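Swapping Butyl for Cyclopentyl on a Well-Tolerated Amide

The source may hold more compounds than are shown below. What is called first, only, known or untested is meant among the compounds shown, and "the series" means these compounds.

Compound 1 (`O=c1nc(N2CCN(CC3CCCCC3)CC2)sc2c([N+](=O)[O-])cc(C(F)(F)F)cc12`) and compound 2 (`CCCCC(=O)N1CCN(c2nc(=O)c3cc(C(F)(F)F)cc([N+](=O)[O-])c3s2)CC1`) share one core and were tested in an ADME assay on Vero cells (Chlorocebus sabaeus) for cytotoxicity, read by MTT assay, with a stated time of 72 h; a lower number here means that less compound is tolerated, a higher number that more compound is tolerated. Compound 1 gives > 125000 nM, which is a limit of the assay and not a number. Compound 2 gives > 125000 nM, which is also a limit. Compound 2 therefore stands at the limit of > 125000 nM in this assay, at which 2 of the 2 values shown sit. Compound 3 (`O=C(C1CCCC1)N1CCN(c2nc(=O)c3cc(C(F)(F)F)cc([N+](=O)[O-])c3s2)CC1`) keeps the core of compound 2 and has cyclopentyl in place of butyl on a carbonyl carbon. Among the compounds with values here, the one measured step that bears on this is a step that the two limits leave unreadable from compound 1 to compound 2, with butylcarbonyl in place of cyclohexylmethyl on an amine nitrogen in a ring. With no readable size to carry over, no change beyond the scatter is expected in this assay. The expected result is a number no higher from compound 2 to compound 3 (the limit leaves the size open). For compound 3 the estimate is 125000 nM, with an expected range from 70000 nM to 250000 nM.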

Compound 3, half-maximal cytotoxic concentration: 120000 nM
The estimate for compound 3 lay 1.0-fold (0.02 log units) above the measured number, and the stated range covers the measured number.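

In this assay, within the data shown here, compound 3 gives 120000 nM, the first value that is a true number and not a limit. Among these compounds, measured against the limits of the earlier compounds, the change to cyclopentyl gives an at least 1.0-fold lower number from compound 2 to compound 3 (0.01 log units; that floor lies within the scatter), and the change from the cyclohexylmethyl compound gives an at least 1.0-fold lower number from compound 1 to compound 3 (0.01 log units; that floor lies within the scatter). A five-membered carbon ring on this carbonyl carbon therefore gives no step beyond the scatter, and the series now has one real number against which later changes can be read.

From the compounds shown here alone, what an amine, a carboxylic acid or a longer chain on this carbonyl carbon would do remains open. The true values of compound 1 and compound 2 also remain unknown, so the step between those two cannot be read and the other two steps have only a floor: the limit of > 125000 nM in this assay, at which 2 of the 3 values shown sit.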